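Shortening the chain on the core nitrogen: compound 3 to 4

The source may hold more compounds than are shown below. What is called first, only, known or untested is meant among the compounds shown, and "the series" means these compounds.

Of the compounds shown here, three sharing one core have been tested in a functional assay on MCF7 cells (Homo sapiens) for antiproliferative activity; a lower number here means a stronger inhibitor, a higher number a weaker inhibitor. Compound 1 `CCC(CC)Cn1c(Cc2cc(OC)c(OC)c(OC)c2)nc2c(N)ncnc21` gives 158000 nM, compound 2 `CCCCCn1c(Cc2cc(OC)c(OC)c(OC)c2)nc2c(N)ncnc21` gives 61700 nM, and compound 3 `COc1cc(Cc2nc3c(N)ncnc3n2CC(OC)OC)cc(OC)c1OC` gives 72400 nM. Among these three numbers compound 3 stands second highest: against compound 2 it lies within the scatter, while compound 1 is set apart, with a 2.2-fold lower number from compound 1 to compound 3 (0.34 log units; beyond the scatter) and a 2.6-fold lower number from compound 1 to compound 2 (0.41 log units; beyond the scatter). The step of a 1.2-fold higher number from compound 2 to compound 3 (0.07 log units; within the scatter) shows that butyl and dimethoxymethyl at that place give numbers that cannot be told apart.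

Compound 4 `COc1cc(Cc2nc3c(N)ncnc3n2C)cc(OC)c1OC` differs from compound 3 in one place: hydrogen in place of dimethoxymethyl on a saturated chain carbon bound to an aromatic nitrogen. The measured steps that touch this position all swap one chain for another; the only one beyond the scatter is the move away from pentan-3-yl, and the exchange of butyl for dimethoxymethyl changed nothing that could be resolved. Among the compounds with values here, removing the chain almost entirely is a larger change than any of these, and no measured step shows what that does. The expectation for compound 4 is therefore a step of a 1.1-fold lower number from compound 3 to compound 4 (0.05 log units; within the scatter) in this assay, essentially no change beyond the scatter, with a wide band of uncertainty. The estimated value for compound 4 is 65000 nM, with a range from 20000 nM to 200000 nM.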

Compound 4, half-maximal inhibitory concentration: 70800 nM
For compound 4 the middle estimate is 1.1-fold (0.04 log units) below the measured one, within the range that was stated.
By their numbers in this assay, from the lowest: compounds 2, 4 and 3 (each within the scatter of the next); then compound 1.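

In this assay, hydrogen in place of dimethoxymethyl gives a 1.0-fold lower number from compound 3 to compound 4 (0.01 log units; within the scatter), and hydrogen in place of butyl gives a 1.1-fold higher number from compound 2 to compound 4 (0.06 log units; within the scatter), so cutting the chain back to a plain methyl costs nothing that can be resolved: the 2,2-dimethoxyethyl group, with its two hydrogen-bond acceptors and five heavy atoms, can go without any visible effect on the number. Within the data shown here, only the step from the pentan-3-yl compound stands out, with hydrogen in its place giving a 2.2-fold lower number from compound 1 to compound 4 (0.35 log units; beyond the scatter), which leaves compound 1 as the one compound set apart from the other three, and shows that a group on this saturated chain carbon is not needed to reach the level of compounds 2, 3 and 4. Nothing further is available here to explain why these numbers fall as they do.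

The compounds shown leave open whether it is the branching of pentan-3-yl that sets compound 1 apart, a question that a smaller branched group such as isopropyl could help to answer. They also leave open whether an amine, a carboxylic acid or a much longer chain at this place would shift the number in either direction.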